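This account rests on a few compounds, and the source may have more. Where it says the series, first, only, none or still open, it means among the compounds named here.

In a functional assay on MCF7 cells (Homo sapiens) for cytotoxicity, read by sulforhodamine B assay, with a stated time of 48 h (a lower number here means a stronger inhibitor of growth, a higher number a weaker inhibitor of growth), compound 1 (`Cc1nn(-c2ccccc2)c(Sc2ccc(-c3nc4cc([N+](=O)[O-])ccc4[nH]3)cc2)c1/C=N/NC(N)=O`) gives 16600 nM, compound 2 (`Cc1nn(-c2ccccc2)c(Oc2ccc(-c3nc4cc(C(=O)O)ccc4[nH]3)cc2)c1/C=N/Nc1ccccc1`) gives 17700 nM, and compound 3 (`Cc1nn(-c2ccccc2)c(Oc2ccc(-c3nc4cc(C(=O)O)ccc4[nH]3)cc2)c1/C=N/NC(N)=S`) gives 18100 nM. These three values lie within the scatter of one another, so compound 3 cannot be told apart from the other two. Compound 4 (`Cc1nn(-c2ccccc2)c(Oc2ccc(-c3nc4cc(C(N)=O)ccc4[nH]3)cc2)c1/C=N/NC(N)=S`) differs from compound 3 in one place: amino in place of hydroxy on a carbonyl carbon. This puts amino in place of hydroxy on a carbonyl carbon, turning carboxy into carbamoyl. Among the measured compounds shown here, the one measured step, a 1.0-fold higher number from compound 2 to compound 3 (0.01 log units; within the scatter), is a swap on an amine nitrogen, so it bears on this change only indirectly. No step beyond the scatter is therefore expected, and the estimate means a 1.1-fold lower number from compound 3 to compound 4 (0.05 log units; within the scatter). For compound 4 the expected value is 16000 nM, with an estimated range of 6000 nM to 40000 nM.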

Compound 4, concentration for 50% growth inhibition: 9600 nM
Compound 4: middle estimate off by 1.7-fold (0.22 log units), on the high side; the measured number falls inside the stated range.
By their numbers in this assay, from the lowest: compounds 4, 1, 2 and 3 (each within the scatter of the next).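

In this assay, among the compounds shown here, the change from carboxy to carbamoyl gives a 1.9-fold lower number from compound 3 to compound 4 (0.28 log units; within the scatter), so this is the first reading of a change at this position. It shows that amino in place of hydroxy on this carbonyl carbon leaves growth inhibition within the scatter, with no effect that can be told apart. Nothing measured here offers an explanation for the result. Still open, as far as these compounds go, is whether a methyl ester or a nitrile in place of carboxy would give a step beyond the scatter. Also open, from the compounds shown here alone, is whether this same swap holds when phenyl sits on the amine nitrogen, as in compound 2.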